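The compounds below may be only part of what the source reports. "The series", "measured", "known", "first", "only" and "open" are said of these compounds alone.

Measured so far:
compound 1 `COc1ccc(C2=NN(C(=O)c3ccc4c(c3)OCCO4)C(c3ccccc3)C2)cc1`: 2370 nM
compound 2 `O=C(c1ccc2c(c1)OCCO2)N1N=C(c2ccccc2)CC1c1ccccc1`: 1370 nM

In a functional assay on WM 266-4 cells (Homo sapiens) for inhibition, read by MTT assay, with a stated time of 24 h (on this read-out higher numbers stand for weaker inhibition of growth and lower numbers for stronger inhibition of growth), compound 1 gives 2370 nM, the highest of the two numbers; the step of a 1.7-fold lower number from compound 1 to compound 2 (0.24 log units; within the scatter) lies within the scatter. Compound 3 `COc1ccc(C2=NN(C(=O)c3ccc4c(c3)OCCO4)C(c3cccc(F)c3)C2)cc1` differs from compound 1 by fluoro in place of hydrogen on an aromatic carbon. Going by the values given here, no measured step bears directly on this change; the one measured step, a change on the other aromatic ring, was within the scatter. A step within the scatter is therefore expected from compound 1 to compound 3, a 1.2-fold lower number from compound 1 to compound 3 (0.07 log units; within the scatter). Compound 3 is estimated at 2000 nM, range 800 nM to 5000 nM.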

Compound 3, concentration for 50% growth inhibition: 930 nM
For compound 3 the middle estimate is 2.2-fold (0.33 log units) above the measured one; the range from low to high includes it.
By their numbers in this assay, from the lowest: compounds 3, 2 and 1 (each within the scatter of the next, the first and the last beyond it).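

In this assay, going by these compounds alone, the change from phenyl to 3-fluorophenyl on the core of compound 1 gives a 2.5-fold lower number from compound 1 to compound 3 (0.41 log units; beyond the scatter), the first step beyond the scatter. The earlier change on the other aromatic ring, a 1.7-fold lower number from compound 1 to compound 2 (0.24 log units; within the scatter), showed no such separation. Growth inhibition therefore responds modestly to a single fluoro at this place on this ring, and nothing measured here accounts for that step. The compounds shown leave open whether chloro, methyl or an amine at the same place would give a similar step. Also open, on these data alone, is whether fluoro has the same effect on the core of compound 2.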